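Swapping the benzoyl of compound 1 for a morpholine urea

The source may hold more compounds than are shown below. What is called first, only, known or untested is meant among the compounds shown, and "the series" means these compounds.

Within the data shown here, compound 1 `CC(C)(C)c1cc(NC(=O)[C@@H]2CCCCN2C(=O)c2ccccc2)no1` has the higher of the two numbers so far in an ADME assay (liver) for metabolic stability, with Liver microsome (Homo sapiens) as the target, read by LC-MS, using microsomes and NADPH, tested at 1 uM; on this read-out lower numbers stand for a shorter-lived compound and higher numbers for a longer-lived compound: compound 1 gives 0.683 h. Its nearest neighbour, compound 2 `CC(C)(C)c1cc(NC(=O)[C@@H]2CCCCN2C(=O)C2CCCCC2)no1`, gives 0.483 h in this assay, and the step of a 1.4-fold lower number from compound 1 to compound 2 (0.15 log units; within the scatter) is within the scatter. Compound 3 `CC(C)(C)c1cc(NC(=O)[C@@H]2CCCCN2C(=O)N2CCOCC2)no1` carries morpholin-4-yl in place of phenyl on a carbonyl carbon. Among the measured compounds shown here, only that step from compound 1 to compound 2 bears on this change, and it was small, so the expected step of a 1.0-fold higher number from compound 1 to compound 3 (0.01 log units; within the scatter) is none beyond the scatter. Compound 3 is therefore estimated at 0.7 h, within 0.35 h to 1.4 h.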

Compound 3, half-life: > 2 h
Compound 3 was reported as a limit; the forecaster's own chance of this, stated with the estimate: 5%; middle value at least 2.8-fold (0.45 log units) from the limit.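

In this assay compound 3 gives > 2 h, which is a limit of the assay and not a number. Even so, this carbonyl carbon proves sensitive to what it carries: morpholin-4-yl gives an at least 2.9-fold higher number from compound 1 to compound 3 (0.46 log units; beyond the scatter) and an at least 4.1-fold higher number from compound 2 to compound 3 (0.61 log units; beyond the scatter). Phenyl and cyclohexyl had stayed within the scatter of each other, so a change of group here need not leave the half-life unmoved.

The compounds shown leave open whether the oxygen of morpholin-4-yl matters, which a piperidin-1-yl group on the same carbonyl carbon would test. How far compound 3 lies past its limit also stays unknown: the limit of > 2 h in this assay, at which 1 of the 3 values shown sits.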